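Removing the Fluorobenzyl Group: Expected Cytotoxicity of Compound 4

The source may report more compounds than this note shows. Statements on the series, on what has been measured and on what is new or still open speak of the compounds shown alone.

The measured compounds in an ADME assay on HCT-116 cells (Homo sapiens) for cytotoxicity, read by CellTiter-Glo, with a stated time of 72 h; on this read-out higher numbers stand for weaker inhibition and lower numbers for stronger inhibition:
Compound 1, `Cc1cc(C)c(S(=O)(=O)N2CCC(N3CCCCCC3)CC2)c(C)c1`: > 5000 nM
Compound 2, `Cc1cc(C)c(S(=O)(=O)N2CCC(N3CCC(Cc4ccccc4)CC3)CC2)c(C)c1`: > 5000 nM
Compound 3, `Cc1cc(C)c(S(=O)(=O)N2CCC(N3CCC(Cc4ccc(F)cc4)CC3)CC2)c(C)c1`: > 5000 nM

Compound 3 sits at the limit of this assay, and its value is a limit rather than a number. The same holds for compound 1 and for compound 2, each reported only as a limit. Within the data shown here, the one comparable step, a step that the two limits leave unreadable from compound 2 to compound 3, cannot be read in size, and the reason is the limit of > 5000 nM in this assay, at which 3 of the 3 values shown sit.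

Compound 4, `Cc1cc(C)c(S(=O)(=O)N2CCC(N3CCCCC3)CC2)c(C)c1`, differs from compound 3 by hydrogen in place of 4-fluorobenzyl on a saturated ring carbon. Compound 1 carries a ring of a different size in the same region and also stands at the limit, so nothing among the shown values suggests that trimming the saturated ring to a bare one brings the compounds into the measurable range. Among the measured compounds shown here, no measured step bears directly on this change, and no difference beyond the scatter can be expected from it.

Compound 4 is therefore expected to show 10000 nM, with a range from 5000 nM to 40000 nM, which would correspond to an estimated step that the limit leaves unreadable from compound 3 to compound 4.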

Compound 4, half-maximal inhibitory concentration: > 5000 nM
Compound 4: no number, only a limit (the forecaster's own chance of this, stated with the estimate: 90%); the middle value lies beyond the limit too.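

In this assay compound 4 gives > 5000 nM as a limit, not a number. Among these compounds, no step from compound 1, compound 2 or compound 3 to compound 4 can be read in size, because all the values stand at one limit: the limit of > 5000 nM in this assay, at which 4 of the 4 values shown sit. The compounds shown leave open whether any of these changes alters the cytotoxicity at all.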